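Chloro in place of hydrogen on an amide-linked aromatic ring

The source may report more compounds than this note shows. Statements on the series, on what has been measured and on what is new or still open speak of the compounds shown alone.

Measured compounds:
compound 1, `O=C(CCCCC1CCSS1)Nc1ccc(Cl)cn1`: 16.1%
compound 2, `CC(=O)SCCC(CCCCC(=O)Nc1ccccc1)SC(C)=O`: "not active" (no number reported)

In a functional assay on Bel-7402 cells (Homo sapiens) for inhibition, read by MTT assay, with a stated time of 24 h, tested at 10 ug/mL (on this read-out higher numbers stand for more inhibition of growth at the one concentration tested and lower numbers for less inhibition of growth), compound 1 gives 16.1%. Compound 2 carries a different core and was reported in this assay only as "not active" (no number reported), so no single number marks where compound 2 stands; it can only be said that its growth inhibition was too small to be given as a figure. Compound 3, `CC(=O)SCCC(CCCCC(=O)Nc1ccc(Cl)cc1)SC(C)=O`, has not been measured. It differs from compound 2 by chloro in place of hydrogen on an aromatic carbon. For the measured compounds named here, compounds 1 and 2 share no step, so nothing measured here says how this change moves the read-out. With compound 2 reported as "not active" (no number reported), the expected step in this assay from compound 2 to compound 3 is none beyond the scatter, in either direction. Compound 3 is therefore estimated at 10%, with an expected range from 0% to 25%.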

Compound 3, percent growth inhibition at one concentration: 5.78%
For compound 3 the middle estimate is 4.2 percentage points above the measured one; the measured number falls inside the stated range.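

For the compounds shown here, compound 2 has no number in this assay but only the words "not active", so no step from it to compound 3 can be read. How chloro in place of hydrogen moves growth inhibition stays open, and no measurement here offers an explanation for the result.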